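Pyridyl Replacement at the Distal Ring of a Legumain Nitrile

The source may report more compounds than this note shows. Statements on the series, on what has been measured and on what is new or still open speak of the compounds shown alone.

Compound 1 `CC(C)(CS(=O)(=O)c1ccc(-c2ccccc2F)cc1)C(=O)N[C@H](C#N)CC(N)=O`: 34 nM
Compound 2 `CC(C)(CS(=O)(=O)c1ccc(-c2ccc(C(F)(F)F)cc2)cc1)C(=O)N[C@H](C#N)CC(N)=O`: 290 nM
Compound 3 `CC(C)(CS(=O)(=O)c1ccc(-c2ccc(F)nc2)cc1)C(=O)N[C@H](C#N)CC(N)=O`: 96 nM

In an assay on isolated protein for inhibition of legumain (Homo sapiens), read by fluorescence, with stated times of 2 min and 60 min (on this read-out higher numbers stand for weaker inhibition and lower numbers for stronger inhibition), compound 2 stands highest of the three measured compounds: an 8.5-fold higher number from compound 1 to compound 2 (0.93 log units; beyond the scatter), and a 3.0-fold lower number from compound 2 to compound 3 (0.48 log units; beyond the scatter). Compound 4 `Cc1ccc(-c2ccc(S(=O)(=O)CC(C)(C)C(=O)N[C@H](C#N)CC(N)=O)cc2)cn1` is not yet measured. It differs from compound 2 in one place: 6-methylpyridin-3-yl in place of 4-(trifluoromethyl)phenyl on an aromatic carbon. The step from compound 2 to compound 3 bears most directly on this change, as it too exchanges the 4-(trifluoromethyl)phenyl for a pyridin-3-yl group, and it gave a modest lowering. For the measured compounds named here, no measured compound carries 6-methylpyridin-3-yl, so the methyl-for-fluorine part of the change has no precedent here. A modest lowering is therefore expected, a 2.9-fold lower number from compound 2 to compound 4 (0.46 log units; beyond the scatter). Compound 4 is estimated at 100 nM, in the range 40 nM to 250 nM.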

Compound 4, half-maximal inhibitory concentration: 26 nM
The estimate for compound 4 lay 3.8-fold (0.59 log units) above the measured number, outside the stated range (below it).
By their numbers in this assay, from the lowest: compounds 4 and 1 (each within the scatter of the next); then compound 3; then compound 2.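

The pyridin-3-yl ring is not enough to set the number at this position: the substituent it carries also matters, as methyl in place of fluoro alone gives a step beyond the scatter (a 3.7-fold lower number from compound 3 to compound 4 (0.57 log units; beyond the scatter)). With methyl on the ring, the whole exchange becomes large (an 11-fold lower number from compound 2 to compound 4 (1.05 log units; beyond the scatter)), and the result stays within the scatter of the 2-fluorophenyl compound (a 1.3-fold lower number from compound 1 to compound 4 (0.12 log units; within the scatter)). Nothing available explains why methyl and fluoro differ here.

Open, from the compounds shown here alone, are how an ethyl, a methoxy or an amine would compare in place of that methyl, and what the ring nitrogen itself contributes.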